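Oxime ether series: ester in place of pyridylmethyl

This account rests on a few compounds, and the source may have more. Where it says the series, first, only, none or still open, it means among the compounds named here.

Measured so far:
compound 1 `C/C(=N\OCc1ccncc1)c1ccc(Sc2cc(F)cc(C3CCOCC3)c2)cc1` — 300 nM
compound 2 `C/C(=N\O)c1cccc(Sc2cc(F)cc(C3CCOCC3)c2)c1` — 2910 nM
compound 3 `CO[C@]1(c2cc(F)cc(Sc3ccc(/C(C)=N/OCC#N)cc3)c2)CCO[C@@H](C)C1` — 40 nM

Going by the values given here, in a functional assay (blood) for inhibition, with Homo sapiens as the target (a lower number here means a stronger inhibitor, a higher number a weaker inhibitor), compound 1 sits second highest of the three numbers, with compound 3 at the lower end and compound 2 at the higher end, both beyond the scatter of compound 1; no single-point steps connect these three. Compound 4 `CCOC(=O)CO/N=C(\C)c1ccc(Sc2cc(F)cc(C3CCOCC3)c2)cc1` is unmeasured; it differs from compound 1 by ethoxycarbonyl in place of pyridin-4-yl on a saturated chain carbon bound to an oxygen. Among the compounds with values here, no measured pair isolates this change, so the step from a 1.5-fold lower number from compound 1 to compound 4 (0.18 log units; within the scatter) is an estimate: a small move toward the lower numbers, possibly not beyond the scatter. Compound 4 is therefore expected near 200 nM, within 60 nM to 700 nM.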

Compound 4, half-maximal inhibitory concentration: 610 nM
Beside the measured number, compound 4's estimate is 3.1-fold (0.48 log units) below it; low and high end bracket the measured number.
By their numbers in this assay, from the lowest: compound 3; then compound 1; then compound 4; then compound 2.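

In this assay, ethoxycarbonyl in place of pyridin-4-yl on a saturated chain carbon bound to an oxygen gives a 2.0-fold higher number from compound 1 to compound 4 (0.31 log units; beyond the scatter) and so shows that activity at this position does not depend on an aromatic ring. The loss is modest, yet the step favours the pyridin-4-yl group of compound 1. Nothing available accounts for this step.

As far as these compounds go, whether the ethyl part or the carbonyl drives the step remains open. The corresponding carboxylic acid or primary amide on the same chain would separate the two.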